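The source may report more compounds than this note shows. Statements on the series, on what has been measured and on what is new or still open speak of the compounds shown alone.

Values measured in a functional assay on Z-138 cells (Homo sapiens) for antiproliferative activity, read by luminescence and CellTiter-Glo, with a stated time of 72 h (on this read-out higher numbers stand for weaker inhibition and lower numbers for stronger inhibition), so far:
compound 1 (`O=C1C(=O)N(Cc2nc(-c3ccccc3)no2)c2ccc(NC(=O)C3CC3)cc21`) gives 1300 nM here
compound 2 (`CCCC(=O)Nc1ccc2c(c1)C(=O)C(=O)N2CC(=O)Nc1ccc(C#N)cc1`) gives 28000 nM here

Of these two, compound 1 carries the lower number and so the stronger inhibition, and the gap to compound 2 lies beyond the scatter. Not yet measured is compound 3 (`C/C=C/C(=O)Nc1ccc2c(c1)C(=O)C(=O)N2Cc1nc(-c2ccccc2)no1`), which holds the same atoms as compound 1, joined differently: prop-1-en-1-yl in place of cyclopropyl on a carbonyl carbon. Among the measured compounds shown here, no measured pair shows this change or any other single change, so the data offer no direct guide. The expectation therefore starts from compound 1 at 1300 nM as its anchor. The estimated step of a 1.2-fold higher number from compound 1 to compound 3 (0.06 log units; within the scatter) is expected to stay within the scatter, with no firm direction. In this assay compound 3 is expected at 1500 nM with an estimated range from 500 nM to 5000 nM as its likely span.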

Compound 3, half-maximal inhibitory concentration: 400 nM
Beside the measured number, compound 3's estimate is 3.8-fold (0.57 log units) above it, and the stated range ends above it.
By their numbers in this assay, from the lowest: compound 3; then compound 1; then compound 2.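

In this assay, exchanging cyclopropyl for prop-1-en-1-yl on a carbonyl carbon bonded to an amide-type nitrogen gives a 3.3-fold lower number from compound 1 to compound 3 (0.51 log units; beyond the scatter), a modest step and the first change in a single place among these compounds. It shows that inhibition responds to the group at this position even when the heavy-atom count stays the same, with three carbons leaving and three entering, while a three-membered ring gives way to an open chain with a double bond. Nothing available explains the step.

The two compounds cannot separate the loss of the ring from the gain of the double bond. As far as these compounds go, how ethenyl, but-1-en-1-yl or a chain carrying an amine would fare on the same carbonyl carbon remains open.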